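Pyridin-3-yl to Pyridin-4-yl: Expected Cytotoxicity

The compounds below may be only part of what the source reports. "The series", "measured", "known", "first", "only" and "open" are said of these compounds alone.

Compound 1, `COc1ccc(S(=O)(=O)/C=C/c2ccccn2)cc1`, gives 100% in an ADME assay on BV-2 cells (Mus musculus) for cytotoxicity, with a stated time of 24 h, tested at 10 uM; a higher number here means a weaker effect of the compound at the concentration tested, a lower number a stronger effect.
Compound 2, `COc1ccc(S(=O)(=O)/C=C/c2cccnc2)cc1`, gives 99.5% in this assay.
Compound 3, `COc1ccc(S(=O)(=O)/C=C/c2cccnc2Cl)cc1`, gives 100% in this assay.

All three numbers sit close to the top of the scale, meaning the cells were essentially unharmed at the tested concentration. Compound 2 holds the smallest number of the three, yet the step of a number 0.5 percentage points lower from compound 1 to compound 2 (within the scatter) and the step of a number 0.5 percentage points higher from compound 2 to compound 3 (within the scatter) both stay within the scatter, so the three compounds cannot be told apart on this read-out.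

Compound 4, `COc1ccc(S(=O)(=O)/C=C/c2ccncc2)cc1`, has not yet been measured. It differs from compound 2 in one place: pyridin-4-yl in place of pyridin-3-yl on a double-bonded chain carbon bound to a double-bonded chain carbon. Among the measured compounds shown here, the measured step that bears most directly on this is the one from compound 1 to compound 2, where the ring was likewise swapped for another ring of the same size and composition at the same place, and the result was a number 0.5 percentage points lower from compound 1 to compound 2 (within the scatter). The step of a number 0.5 percentage points higher from compound 2 to compound 3 (within the scatter) adds that even a further change to the ring left the number unmoved. On this basis no step beyond the scatter is expected in this assay from compound 2 to compound 4, giving an expected step of no change at the digits printed from compound 2 to compound 4 (within the scatter). Compound 4 is therefore estimated at 99.5%, with a range from 94% to 100%.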

Compound 4, a percentage reported as activity, at one concentration (the size of the read-out at that concentration, not a potency): 71%
The estimate for compound 4 lay 28.5 percentage points above the measured number; the whole stated range lies above it.
By their numbers in this assay, from the lowest: compound 4; then compounds 2, 1 and 3 (each within the scatter of the next).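

At this place on the chain, the swap among these ring groups is no longer silent in this assay: pyridin-4-yl gives a number that stands apart from both earlier groups, with a number 28.5 percentage points lower from compound 2 to compound 4 (beyond the scatter) and a number 29 percentage points lower from compound 1 to compound 4 (beyond the scatter), whereas pyridin-2-yl and pyridin-3-yl could not be told apart. The groups exchanged have the same atoms, the same kind of six-membered aromatic ring and the same donor and acceptor counts, so a change that leaves all these counts untouched can still separate compounds on this read-out. Nothing available here says why pyridin-4-yl behaves differently from the other two groups.

From the compounds shown here alone, it remains open whether the lower number belongs to pyridin-4-yl alone or would also appear with other groups at this place, such as a plain phenyl ring or a pyrimidinyl ring. It is also open whether a chloro group on the pyridin-4-yl ring would leave the number where it is or move it, given that the only chloro compound shown carries pyridin-3-yl.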